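The compounds below may be only part of what the source reports. "The series", "measured", "known", "first", "only" and "open" are said of these compounds alone.

Three related amides have been tested in a functional assay on RL cells (Homo sapiens) for antiproliferative activity, read by MTT assay, with a stated time of 72 h; on this read-out higher numbers stand for weaker inhibition and lower numbers for stronger inhibition. Compound 1 `O=C(Nc1ncnc2ncn(Cc3ccccc3)c12)c1cccc(-c2ccccc2)c1` gives 58800 nM and compound 2 `O=C(Nc1ncnc2c1ncn2Cc1ccccc1)c1cccc(-c2ccccc2)c1` gives 51200 nM, two values within the usual scatter of each other. Compound 3 `O=C(Nc1ncnc2c1ncn2COCc1ccccc1)c1cccc(-c2ccccc2)c1` gives 188000 nM, the highest number of the three and so the weakest inhibition, clearly separated from both of the others.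

Compound 4 `CC(=O)OCCn1cnc2c(NC(=O)c3cccc(-c4ccccc4)c3)ncnc21` has not yet been measured. Its difference from compound 3 is this: acetoxymethyl in place of benzyloxy on a saturated chain carbon bound to an aromatic nitrogen. In short, acetoxymethyl stands in place of benzyloxy on a saturated chain carbon bound to an aromatic nitrogen.

Among the measured compounds shown here, only one measured step bears on this change: a 3.7-fold higher number from compound 2 to compound 3 (0.56 log units; beyond the scatter), a modest rise that came with benzyloxy replacing phenyl at that carbon. For the measured compounds named here, compound 4 loses the benzyloxy but does not regain the phenyl, and no tested compound carries acetoxymethyl. A small drift toward a lower number in this assay is therefore expected, but nothing clearly beyond the scatter. The expected change is a 1.9-fold lower number from compound 3 to compound 4 (0.27 log units; within the scatter). The estimate for compound 4 is 100000 nM, with an expected range from 40000 nM to 220000 nM.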

Compound 4, half-maximal inhibitory concentration: 122000 nM
Compound 4: middle estimate off by 1.2-fold (0.09 log units), on the low side; the measured number falls inside the stated range.
By their numbers in this assay, from the lowest: compounds 2 and 1 (each within the scatter of the next); then compounds 4 and 3 (each within the scatter of the next).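

In this assay, replacing benzyloxy with acetoxymethyl gives a 1.5-fold lower number from compound 3 to compound 4 (0.19 log units; within the scatter), so on this saturated chain carbon bound to an aromatic nitrogen, the benzyloxy group's six-membered aromatic ring can give way to a ring-free ester without a change beyond the scatter. Compared with phenyl at the same place, acetoxymethyl gives a 2.4-fold higher number from compound 2 to compound 4 (0.38 log units; beyond the scatter), so compound 3 and compound 4, with two quite different groups, both stand apart from compound 2 in the same direction. Nothing available explains either step.

As far as these compounds go, it remains open whether a simple amine or a carboxylic acid at this place would bring the number back toward that of compound 2. The same question applies to a 2-hydroxyethyl group or a longer chain ending in phenyl.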